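Compound 2 to compound 4: swapping the aryl group

A few compounds are considered here, and "the series" means these few. Any claim that something is new, unique, unknown or untested is made for them only; others in the source may bear on it.

Values measured in a functional assay on SMMC-7721 cells (Homo sapiens) for antiproliferative activity, read by CCK-8 assay, with a stated time of 72 h (a higher number here means a weaker inhibitor, a lower number a stronger inhibitor), are these:
Compound 1 `Nc1ccccc1NC(=O)c1ccc(CSC(=S)N2CCN(c3ccccc3)CC2)cc1` gives 2860 nM
Compound 2 `Nc1ccccc1NC(=O)c1ccc(CSC(=S)N2CCN(c3ccc(F)cc3)CC2)cc1` gives > 32000 nM (a limit, not a number)
Compound 3 `CCN(Cc1ccncc1)C(=S)SCc1ccc(C(=O)Nc2ccccc2N)cc1` gives 1210 nM

Compound 2 has no number, only a limit, namely the limit of > 32000 nM in this assay, at which 1 of the 3 values shown sits (no more can be said of its place in the series). Compound 4 `Nc1ccccc1NC(=O)c1ccc(CSC(=S)N2CCN(c3ccncc3)CC2)cc1` carries pyridin-4-yl in place of 4-fluorophenyl on an amine nitrogen in a ring. For the measured compounds named here, one measured step bears on this change, with fluoro in place of hydrogen on an aromatic carbon (an at least 11-fold higher number from compound 1 to compound 2 (1.04 log units; beyond the scatter)). Going by the values given here, it is large and beyond the scatter, and it is the only step in which compound 2 takes part. Compound 4 has no fluoro and, like compound 1, has an unsubstituted aromatic ring at this place. Compound 3 also holds a pyridin-4-yl group, in another setting, and gives 1210 nM as a measured number. A large step to a lower number is therefore expected in this assay, of about the size seen between compound 1 and compound 2. The estimated step is given here (an at least 12-fold lower number from compound 2 to compound 4 (1.10 log units; beyond the scatter)). The estimated value for compound 4 is 2500 nM (expected range 600 nM to 12000 nM).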

Compound 4, half-maximal inhibitory concentration: 1340 nM
The estimate for compound 4 lay 1.9-fold (0.27 log units) above the measured number; low and high end bracket the measured number.
By their numbers in this assay, from the lowest: compounds 3 and 4 (each within the scatter of the next); then compound 1. At a limit, above all of these: compound 2.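

In this assay, the aromatic group on the amine nitrogen in a ring can now be read in both directions from phenyl, since pyridin-4-yl in place of phenyl gives a 2.1-fold lower number from compound 1 to compound 4 (0.33 log units; beyond the scatter), a modest step that lies just beyond the scatter. Set against the loss seen with 4-fluorophenyl, the same swap starting from the fluorinated compound gives an at least 23-fold lower number from compound 2 to compound 4 (1.37 log units; beyond the scatter), which shows that the outcome at this position depends strongly on which six-membered aromatic ring is present, and that keeping a ring here is compatible with a measured number in this series. The size of that large step has a floor and no fixed value, as compound 2 has only a limit, not a number: the limit of > 32000 nM in this assay, at which 1 of the 4 values shown sits.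

Going by these compounds, whether a chloro or methoxy group on the phenyl ring would behave like the fluoro of compound 2 remains open. On these data alone, it is also open whether pyridin-3-yl or pyridin-2-yl would match pyridin-4-yl, or whether a saturated group such as cyclohexyl could take the place of the aromatic ring.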